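The source may report more compounds than this note shows. Statements on the series, on what has been measured and on what is new or still open speak of the compounds shown alone.

Of the compounds shown here, three sharing one core have been tested in a functional assay on C6 cells (Rattus norvegicus) for cytotoxicity, read by MTT assay, with a stated time of 24 h, tested at 200 ug/mL; a lower number here means a stronger effect, a higher number a weaker effect of the compound at the concentration tested. Compound 1, with structure `Cc1nnc(SCC(=O)N/N=c2/scc(-c3ccc(F)cc3)n2-c2ccccc2)s1`, gives 26.5%. Compound 2, with structure `Cc1ccc(-c2cs/c(=N/NC(=O)CSc3ncccn3)n2-c2ccccc2)cc1`, gives 43.7%. Compound 3, with structure `O=C(CSc1ncccn1)N/N=c1/scc(-c2ccc(F)cc2)n1-c1ccccc1`, gives 32.2%. Compound 2 stands highest of the three, and its gaps to the other two lie beyond the usual scatter. Compound 2 and compound 3 differ only by methyl in place of fluoro on an aromatic carbon, which brings a number 11.5 percentage points lower from compound 2 to compound 3 (beyond the scatter). Compound 3 and compound 1 differ by 5-methyl-1,3,4-thiadiazol-2-yl in place of pyrimidin-2-yl on a sulfur, and that step is a number 5.7 percentage points lower from compound 3 to compound 1 (within the scatter).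

Compound 4, with structure `Cc1ccc(-c2cs/c(=N/NC(=O)CSc3nnc(C)s3)n2-c2ccccc2)cc1`, has not yet been measured. It differs from compound 2 by 5-methyl-1,3,4-thiadiazol-2-yl in place of pyrimidin-2-yl on a sulfur, the same change that turns compound 3 into compound 1, made at the same place on the same kind of sulfur. The two starting cores differ by methyl in place of fluoro on an aromatic carbon. Since that change once gave a number 5.7 percentage points lower from compound 3 to compound 1 (within the scatter), a step of about the same small size is expected here, namely a number 5.7 percentage points lower from compound 2 to compound 4 (within the scatter). Compound 4 is therefore expected to give about 38% in this assay, most likely between 28% and 50%.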

Compound 4, a percentage reported as activity, at one concentration (the size of the read-out at that concentration, not a potency): 13.3%
For compound 4 the middle estimate is 24.7 percentage points above the measured one, and the stated range ends above it.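

In this assay, the change to 5-methyl-1,3,4-thiadiazol-2-yl in place of pyrimidin-2-yl on the sulfur did not keep its size from one core to the other, and on the methyl-bearing core it shows a number 30.4 percentage points lower from compound 2 to compound 4 (beyond the scatter): the same change on two cores in this assay, a number 5.7 percentage points lower (within the scatter) from compound 3 to compound 1 and a number 30.4 percentage points lower (beyond the scatter) from compound 2 to compound 4, 24.7 percentage points apart, beyond the scatter of two such steps. The second change in this set of four compounds, methyl in place of fluoro on an aromatic carbon, shows a number 13.2 percentage points lower from compound 1 to compound 4 (beyond the scatter), yet it acts in the opposite direction when pyrimidin-2-yl is on the sulfur: the same change on two cores in this assay, a number 11.5 percentage points lower (beyond the scatter) from compound 2 to compound 3 and a number 13.2 percentage points higher (beyond the scatter) from compound 4 to compound 1, 24.7 percentage points apart, beyond the scatter of two such steps. So in these compounds the effect of one change depends on the group at the other place, and a step measured on one core is a poor guide to the same step on another, but the data do not show why this happens or whether it extends beyond these four compounds.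

From the compounds shown here alone, it remains open whether this dependence also appears with a chloro or methoxy group on the aromatic ring. The same question applies to a pyridin-2-yl or a 1,3,4-oxadiazol-2-yl group on the sulfur.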